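The step from compound 2 to compound 3

The source may hold more compounds than are shown below. What is called first, only, known or untested is meant among the compounds shown, and "the series" means these compounds.

Compound 1 `COc1ccc(/C=C\c2cc(OC)c(OC)c(OC)c2)cc1OCc1ccc(CN2CCCCC2C(=O)O)cc1` gives > 50000 nM as a limit
Compound 2 `COc1ccc(/C=C\c2cc(OC)c(OC)c(OC)c2)cc1OCc1ccc(CN2CC(C(=O)O)C2)cc1` gives > 50000 nM as a limit

Both entries come from an ADME assay on NCM460 cells (Homo sapiens) for cytotoxicity, read by CCK-8 assay, with a stated time of 48 h (on this read-out lower numbers stand for stronger inhibition and higher numbers for weaker inhibition), and both are limits of the assay, not numbers. Compound 2 stands at > 50000 nM and this is only a limit. Both compounds rest at the same ceiling (the limit of > 50000 nM in this assay, at which 2 of the 2 values shown sit), so they cannot be ranked against each other. Among the measured compounds shown here, the one measured step (a step that the two limits leave unreadable from compound 1 to compound 2) changes the same place as the step ahead, yet it gives no size to carry forward.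

Compound 3 `COc1ccc(/C=C\c2cc(OC)c(OC)c(OC)c2)cc1OCc1ccc(CNCCNC(C)=O)cc1` keeps the shared core and changes that place ((2-acetamidoethyl)amino in place of 3-carboxyazetidin-1-yl on a saturated chain carbon bound to an aromatic carbon), with (2-acetamidoethyl)amino in place of 3-carboxyazetidin-1-yl on a saturated chain carbon bound to an aromatic carbon. For the measured compounds named here, compound 1 and compound 2 both carry a carboxy group there and compound 3 does not, so no measured step covers this change. Compound 3 is expected to stay near the limit in this assay or to move modestly toward stronger inhibition, and a further limit would be no surprise. The expected step (an at least 1.2-fold lower number from compound 2 to compound 3 (0.09 log units; that floor lies within the scatter)) is only a rough estimate. For compound 3 the estimated value is 40000 nM (expected range 8000 nM to 100000 nM).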

Compound 3, half-maximal inhibitory concentration: 54000 nM
Compound 3: middle estimate off by 1.4-fold (0.13 log units), on the low side, and the stated range covers the measured number.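

No step to compound 3 can be read from compound 1 or compound 2, because those two compounds give only a limit and not a number: the limit of > 50000 nM in this assay, at which 2 of the 3 values shown sit.

The compounds shown leave open whether (2-acetamidoethyl)amino in place of either carboxy-bearing group changes the read-out in this assay at all, and by how much.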